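The source may report more compounds than this note shows. Statements on the series, on what has been measured and on what is new or still open speak of the compounds shown alone.

Measured compounds in an assay on isolated protein for inhibition of alkaline phosphatase, tissue-nonspecific isozyme (Homo sapiens); on this read-out higher numbers stand for weaker inhibition and lower numbers for stronger inhibition:
- compound 1, `COc1ccc(Cl)cc1S(=O)(=O)Nc1cncc(-c2cccnc2)c1`, gives 73 nM
- compound 2, `COc1ccc(Cl)cc1S(=O)(=O)Nc1cncc(-c2ccccc2C)c1`, gives 178 nM
- compound 3, `COc1ccc(Cl)cc1S(=O)(=O)Nc1cncc(-c2ccc(C)cc2)c1`, gives 147 nM

All three share one core and differ only in the aryl group attached to it. Compound 3 carries the 4-methylphenyl group, and its number in this assay differs from that of compound 2 and from that of compound 1 only within the usual scatter, so no ranking among the three can be drawn from these values alone. The measured steps show this: a 2.4-fold higher number from compound 1 to compound 2 (0.39 log units; beyond the scatter) is a modest shift, a 2.0-fold higher number from compound 1 to compound 3 (0.30 log units; within the scatter) stays within the scatter, and a 1.2-fold lower number from compound 2 to compound 3 (0.08 log units; within the scatter) is likewise within the scatter.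

Compound 4, `COc1ccc(Cl)cc1S(=O)(=O)Nc1cncc(-c2cccc(C)c2)c1`, is built from the same atoms as compound 3, joined differently: 3-methylphenyl in place of 4-methylphenyl on an aromatic carbon. The step that bears most directly on this change is the one between the two methylphenyl isomers already measured, a 1.2-fold lower number from compound 2 to compound 3 (0.08 log units; within the scatter), which was too small to count. Moving the methyl group around the phenyl ring has so far not produced a shift beyond the scatter, so for compound 4 the expected step in this assay is a 1.0-fold higher number from compound 3 to compound 4 (0.01 log units; within the scatter), essentially none. Compound 4 is therefore estimated at about 150 nM, with a likely range from 75 nM to 300 nM.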

Compound 4, half-maximal inhibitory concentration: 160 nM
Compound 4: the middle estimate sits 1.1-fold (0.03 log units) below what was measured; low and high end bracket the measured number.
By their numbers in this assay, from the lowest: compounds 1, 3, 4 and 2 (each within the scatter of the next, the first and the last beyond it).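

With compound 4, all three methylphenyl isomers have been read in this assay, and the methyl group's location on the phenyl ring shows no effect beyond the scatter: the 3-methylphenyl compound matches both of its isomers, with a 1.1-fold higher number from compound 3 to compound 4 (0.04 log units; within the scatter) and a 1.1-fold lower number from compound 2 to compound 4 (0.05 log units; within the scatter) as the two steps. Against the pyridin-3-yl group, the new compound gives a 2.2-fold higher number from compound 1 to compound 4 (0.34 log units; beyond the scatter) as a modest step, so compound 2 and compound 4 both have numbers beyond the scatter of compound 1, while compound 3 goes against any such general separation, with a 2.0-fold higher number from compound 1 to compound 3 (0.30 log units; within the scatter) as its step. Nothing available explains these numbers or the small differences among the methylphenyl isomers.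

Going by these compounds, it remains open how pyridin-4-yl or unsubstituted phenyl would compare with the pyridin-3-yl group of compound 1. On these data alone, it is also open whether a methoxy group, an amine or a carboxylic acid on the phenyl ring would show the same lack of dependence on location that the methyl group shows here.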